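Carbonyl aryl group variation in the enone series: compound 4

The source may report more compounds than this note shows. Statements on the series, on what has been measured and on what is new or still open speak of the compounds shown alone.

Measured compounds:
compound 1, `COc1ccc(-c2cc3ccccc3nc2/C=C/C(=O)c2ccc(O)cc2)cc1`: 6930 nM
compound 2, `COc1ccc(-c2cc3ccccc3nc2/C=C/C(=O)c2ccc(OC)c(OC)c2)cc1`: 7540 nM
compound 3, `COc1ccc(-c2cc3ccccc3nc2/C=C/C(=O)c2ccccn2)cc1`: 6260 nM

All three share the core of compound 1 and differ only in the group on the carbonyl carbon. In a functional assay on NCI-H460 cells (Homo sapiens) for antiproliferative activity, read by XTT assay, with a stated time of 72 h (a lower number here means a stronger inhibitor, a higher number a weaker inhibitor), the three numbers sit close together: a 1.1-fold higher number from compound 1 to compound 2 (0.04 log units; within the scatter), a 1.1-fold lower number from compound 1 to compound 3 (0.04 log units; within the scatter) and a 1.2-fold lower number from compound 2 to compound 3 (0.08 log units; within the scatter). Compound 3 holds the lowest of the three numbers, but its gaps to compound 1 and to compound 2 both lie within the scatter, so no order among the three can be read.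

Compound 4, `COc1ccc(-c2cc3ccccc3nc2/C=C/C(=O)c2ccc(Br)s2)cc1`, continues the same kind of exchange: 5-bromothiophen-2-yl in place of pyridin-2-yl on a carbonyl carbon. The three measured steps all bear on it, since each also exchanges the group on the carbonyl carbon, and none moved the number beyond the scatter. For compound 4 no step beyond the scatter is therefore expected, and the estimated change is a 1.0-fold higher number from compound 3 to compound 4 (0.02 log units; within the scatter). The estimate for compound 4 in this assay is 6500 nM, with a range from 3000 nM to 14000 nM.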

Compound 4, half-maximal inhibitory concentration: 5170 nM
Beside the measured number, compound 4's estimate is 1.3-fold (0.10 log units) above it; measured number inside the range.
By their numbers in this assay, from the lowest: compounds 4, 3, 1 and 2 (each within the scatter of the next).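

In this assay the exchange on the carbonyl carbon now reaches a five-membered aromatic ring carrying bromine, and the number still does not move beyond the scatter: a 1.2-fold lower number from compound 3 to compound 4 (0.08 log units; within the scatter) against pyridin-2-yl, a 1.5-fold lower number from compound 2 to compound 4 (0.16 log units; within the scatter) against 3,4-dimethoxyphenyl and a 1.3-fold lower number from compound 1 to compound 4 (0.13 log units; within the scatter) against 4-hydroxyphenyl. The four aromatic groups now differ in ring size and in hetero atom, and no order among compounds 1 to 4 can be read, so in this series neither the change of ring nor the entry of sulfur and bromine separates the compounds. No supporting measurement bears on this result.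

Open, on these data alone, is whether a group without an aromatic ring on the carbonyl carbon, such as an aliphatic amine, a carboxylic acid or a longer alkyl chain, would shift the number. Also open, as far as these compounds go, is whether the same exchanges stay flat when the rest of the shared core is altered.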